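A few compounds are considered here, and "the series" means these few. Any claim that something is new, unique, unknown or untested is made for them only; others in the source may bear on it.

Measured so far in a functional assay on HCT-116 cells (Homo sapiens) for inhibition, read by MTT assay, with a stated time of 72 h; a lower number here means a stronger inhibitor, a higher number a weaker inhibitor:
- compound 1 `CCCNc1cc(-c2ccccc2)nc2cc(OC)cc(OC)c12` gives 970 nM
- compound 2 `COc1cc(OC)c2c(NC3CCCCC3)cc(-c3ccccc3)nc2c1` gives 3820 nM

Compound 2 stands at the higher, weaker end of these two numbers; its nearest neighbour is compound 1, and the step of a 3.9-fold higher number from compound 1 to compound 2 (0.60 log units; beyond the scatter) is modest but beyond the scatter. Compound 3 `COc1cc(OC)c2c(NCc3ccccc3)cc(-c3ccccc3)nc2c1` is not yet measured. The change to reach it is benzyl in place of cyclohexyl on a nitrogen on an aromatic ring. Among the measured compounds shown here, the only measured step that bears on this position is a 3.9-fold higher number from compound 1 to compound 2 (0.60 log units; beyond the scatter), which came with cyclohexyl in place of propyl at the same nitrogen; it shows that the group on this nitrogen moves the number by a modest amount. Nothing measured tells how an aromatic ring compares with a saturated one here, so no direction is secured. The expectation for compound 3 is a step of a 1.5-fold lower number from compound 2 to compound 3 (0.18 log units; within the scatter) in this assay, at or near the scatter. For compound 3 the estimate is 2500 nM, within 900 nM to 7000 nM.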

Compound 3, half-maximal inhibitory concentration: 12000 nM
For compound 3 the middle estimate is 4.8-fold (0.68 log units) below the measured one; measured number above the stated range.
By their numbers in this assay, from the lowest: compound 1; then compound 2; then compound 3.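

In this assay, among the compounds shown here, the saturated and the aromatic six-membered ring are not interchangeable on this nitrogen: benzyl in place of cyclohexylgives a 3.1-fold higher number from compound 2 to compound 3 (0.50 log units; beyond the scatter), which settles a direction the earlier compounds left unknown. Set against the propyl group, the benzyl group gives a 12-fold higher number from compound 1 to compound 3 (1.09 log units; beyond the scatter), the largest step in the series, so among these three compounds the number rises from propyl through cyclohexyl to benzyl, and both ring-bearing groups lie on the weaker side of the open chain. No measurement offered here accounts for this order.

Still open, from the compounds shown here alone, is how a longer chain, such as hexyl, or a shorter one, such as ethyl, compares with propyl on this nitrogen. Also open, going by these compounds, is whether a terminal amine or hydroxyl group on the chain would move the number in either direction.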